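Trifluoromethyl in place of cyano: working notes on the series

The source may report more compounds than this note shows. Statements on the series, on what has been measured and on what is new or still open speak of the compounds shown alone.

Compound 1 (`COc1ccc([C@H]2CC(=O)N(Cc3cccc(C#N)c3)C2)cc1OC1CCCC1`): > 10000 nM in a functional assay on HEK293 cells (Homo sapiens) for cytotoxicity (on this read-out higher numbers stand for lower toxicity in this test and lower numbers for higher toxicity in this test), as a limit
Compound 2 (`COc1ccc([C@H]2CC(=O)N(c3cccc(N)c3C)C2)cc1OC1CCCC1`): > 10000 nM as a limit
Compound 3 (`COc1ccc([C@H]2CC(=O)N(c3ccc(C#N)cc3)C2)cc1OC1CCCC1`): > 10000 nM as a limit

Compound 3 stands at > 10000 nM in this assay and that value is a limit of the assay, not a number. For the measured compounds named here, the series so far comes down to the limit of > 10000 nM in this assay, at which 3 of the 3 values shown sit, and no compound has a number, so compound 3 cannot be ranked against compound 1 or compound 2.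

Compound 4 (`COc1ccc([C@H]2CC(=O)N(c3ccc(C(F)(F)F)cc3)C2)cc1OC1CCCC1`) follows from compound 3 through one change: trifluoromethyl in place of cyano on an aromatic carbon. In words, trifluoromethyl stands in place of cyano on an aromatic carbon, para to a large group.

The measured steps that bear on this are a step that the two limits leave unreadable from compound 1 to compound 3 and a step that the two limits leave unreadable from compound 2 to compound 3. Each replaces the whole group on the amide-type nitrogen, neither replaces cyano alone, and neither gives a size to carry over. All three different groups nevertheless end at the same limit, so no step beyond the usual scatter is expected in this assay and no direction can be assigned. The expected outcome is a step that the limit leaves unreadable from compound 3 to compound 4 and a further limit is the likeliest report. Compound 4 is estimated at 15000 nM with an expected range from 8000 nM to 40000 nM in this assay.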

Compound 4, half-maximal cytotoxic concentration: > 10000 nM
Compound 4 gave a limit, no number (the forecaster's own chance of this, stated with the estimate: 85%); the middle value lies beyond the limit too.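

No step from compound 1, compound 2 or compound 3 to compound 4 can be read, since the series still comes down to one limit of the assay and not a number: the limit of > 10000 nM in this assay, at which 4 of the 4 values shown sit.

Left open is how compound 1, compound 2, compound 3 and compound 4 rank against one another in this assay, including whether trifluoromethyl and cyano differ there at all.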